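Swapping the aryl group on the hydrazone carbon

The compounds below may be only part of what the source reports. "The series", "measured", "known", "first", "only" and "open" are said of these compounds alone.

Compound 2 `CN(C)CCn1cnnc1-c1cc(Oc2ccc(NC(=O)N/N=C/c3ccccc3O[N+](=O)[O-])cc2F)ccn1` was tested in a functional assay on U-87MG ATCC cells (Homo sapiens) for cytotoxicity, read by MTT assay, with a stated time of 72 h (on this read-out lower numbers stand for stronger inhibition and higher numbers for weaker inhibition), where compound 2 gives 7150 nM. Among the measured compounds shown here, its only comparator is compound 1 `COc1ccc(/C=N/NC(=O)Nc2ccc(Oc3ccnc(-c4nncn4CCN(C)C)c3)c(F)c2)c(OC)c1`, which in this assay gives 12600 nM; the step of a 1.8-fold lower number from compound 1 to compound 2 (0.25 log units; within the scatter) does not separate the two beyond the scatter, so neither stands out. Compound 3 `COc1cc(/C=N/NC(=O)Nc2ccc(Oc3ccnc(-c4nncn4CCN(C)C)c3)c(F)c2)cc(OC)c1OC` differs from compound 2 in one place: 3,4,5-trimethoxyphenyl in place of 2-(nitrooxy)phenyl on a carbon with a double bond to nitrogen. For the measured compounds named here, the one measured step that bears on this change is a 1.8-fold lower number from compound 1 to compound 2 (0.25 log units; within the scatter), where a dimethoxyphenyl gave way to the nitrooxyphenyl without a change beyond the scatter. Compound 3 returns to a methoxy-bearing ring, so a number close to compound 1 is expected, meaning a step of a 1.4-fold higher number from compound 2 to compound 3 (0.15 log units; within the scatter) that is expected to stay within the scatter. Compound 3 is therefore estimated at 10000 nM in this assay, with a likely range from 4000 nM to 30000 nM.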

Compound 3, half-maximal inhibitory concentration: 22500 nM
Compound 3: the middle estimate sits 2.3-fold (0.35 log units) below what was measured; the range from low to high includes it.
By their numbers in this assay, from the lowest: compounds 2, 1 and 3 (each within the scatter of the next, the first and the last beyond it).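

In this assay, the aryl group on the carbon with a double bond to nitrogen now gives its first step beyond the scatter: 3,4,5-trimethoxyphenyl in place of 2-(nitrooxy)phenyl gives a 3.1-fold higher number from compound 2 to compound 3 (0.50 log units; beyond the scatter) as a modest change. The two methoxy-bearing rings stay unresolved, with 3,4,5-trimethoxyphenyl in place of 2,4-dimethoxyphenyl giving a 1.8-fold higher number from compound 1 to compound 3 (0.25 log units; within the scatter) and so no separation between them. Compound 2 therefore differs clearly from compound 3 but not from compound 1, and nothing measured here accounts for that difference.

The compounds shown leave open what a ring bearing an amine or a carboxylic acid would do at this position, or a cyclohexyl ring in place of the aromatic one. As far as these compounds go, it also remains open how a plain phenyl ring would compare with the nitrooxy-bearing and methoxy-bearing rings.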